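This account rests on a few compounds, and the source may have more. Where it says the series, first, only, none or still open, it means among the compounds named here.

Measured in a functional assay on MCF7 cells (Homo sapiens) for inhibition, read by MTT assay; a higher number here means a weaker inhibitor of growth, a lower number a stronger inhibitor of growth:

- compound 1 `COc1cc2oc(-c3cccc(NC(=O)c4ccc(Br)cc4)c3)cc(=O)c2c(OC)c1OC`: 9650 nM
- compound 2 `COc1cc2oc(-c3cccc(NC(=O)c4ccccc4Br)c3)cc(=O)c2c(OC)c1OC`: 55000 nM
- compound 3 `COc1cc2oc(-c3cccc(NC(=O)c4ccc(Cl)cc4)c3)cc(=O)c2c(OC)c1OC`: 8780 nM

Compound 3 stands at the low end of these numbers, but it is not separated from its closest neighbour: a 1.1-fold lower number from compound 1 to compound 3 (0.04 log units; within the scatter). The gap to the high end is larger: a 6.3-fold lower number from compound 2 to compound 3 (0.80 log units; beyond the scatter).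

Compound 4 `COc1cc2oc(-c3cccc(NC(=O)c4cccc(C#N)c4)c3)cc(=O)c2c(OC)c1OC` has 3-cyanophenyl in place of 4-chlorophenyl on a carbonyl carbon. Going by the values given here, no measured compound carries a 3-cyanophenyl group, so no step measures this change directly, and the evidence is indirect. The exchange of bromo for chloro in compound 3 made no difference beyond the scatter. Among the compounds with values here, the one step that altered the substitution pattern of the ring did, as compound 2 shows: a 5.7-fold higher number from compound 1 to compound 2 (0.76 log units; beyond the scatter). Compound 4 also gives up the 4-substituted ring, so a rise is expected, though a smaller one than that seen for compound 2, and with wide uncertainty.

The expected step is a 1.8-fold higher number from compound 3 to compound 4 (0.26 log units; within the scatter).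

For compound 4 the estimated value is 16000 nM.

The expected range for compound 4 runs from 6500 nM to 45000 nM.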

Compound 4, concentration for 50% growth inhibition: 41700 nM
Compound 4: middle estimate off by 2.6-fold (0.42 log units), on the low side; low and high end bracket the measured number.
By their numbers in this assay, from the lowest: compounds 3 and 1 (each within the scatter of the next); then compounds 4 and 2 (each within the scatter of the next).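

In this assay, a ring with a group other than halogen also moves the number on this carbonyl carbon: 3-cyanophenyl in place of 4-chlorophenyl gives a 4.7-fold higher number from compound 3 to compound 4 (0.68 log units; beyond the scatter), and 3-cyanophenyl in place of 4-bromophenyl gives a 4.3-fold higher number from compound 1 to compound 4 (0.64 log units; beyond the scatter). The 3-cyanophenyl and 2-bromophenyl rings cannot be told apart, with a 1.3-fold lower number from compound 2 to compound 4 (0.12 log units; within the scatter), so among these four compounds the 4-chlorophenyl and 4-bromophenyl amides form the low pair and the other two the high pair, with no compound shown going against that split. Nothing shown gives a measured reason for this split.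

The change to compound 4 alters both the group and its place on the ring, so the compounds shown do not settle whether the nitrile or its place goes with the higher number; 4-cyanophenyl and 3-chlorophenyl amides would separate the two. From the compounds shown here alone, it also stays open whether the low numbers extend to other groups in the same place, such as a 4-methoxyphenyl or 4-aminophenyl ring, and how the plain phenyl amide compares.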